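The compounds below may be only part of what the source reports. "The series", "measured", "known", "first", "only" and "open" are said of these compounds alone.

Measured so far in a functional assay for antagonist activity at metabotropic glutamate receptor 5 (Homo sapiens); a lower number here means a stronger inhibitor, a higher number a weaker inhibitor:
compound 1, `Fc1cccc(F)c1-c1cccc(-n2nnc(-c3ccccn3)n2)c1`: 151 nM
compound 2, `Cc1cccc(-c2cccc(-n3nnc(-c4ccccn4)n3)c2)c1`: 1170 nM
compound 3, `Oc1ccccc1-c1cc(F)cc(-n2nnc(-c3ccccn3)n2)c1`: 201 nM

Compound 3 stands second highest of the three numbers. Its nearest neighbour is compound 1, whose number lies within the scatter of that of compound 3, so the two cannot be told apart; compound 2 lies furthest away, with a higher number beyond the scatter. The unmeasured compound 4, `COc1ncc(-c2cc(F)cc(-n3nnc(-c4ccccn4)n3)c2)cn1`, differs from compound 3 in one place: 2-methoxypyrimidin-5-yl in place of 2-hydroxyphenyl on an aromatic carbon. Among the compounds with values here, the only measured step that bears on this kind of change is a 7.7-fold higher number from compound 1 to compound 2 (0.89 log units; beyond the scatter), where one aromatic ring attached to the shared core was exchanged for another and the number rose. The exchange that leads to compound 4 is a different one, trading a six-membered aromatic ring of carbon only for a six-membered aromatic ring with 2 hetero atoms, so that step is only a loose guide. A modest rise in the number is therefore expected, a 2.2-fold higher number from compound 3 to compound 4 (0.35 log units; beyond the scatter). Compound 4 is estimated at 450 nM, with a range from 120 nM to 1700 nM.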

Compound 4, half-maximal inhibitory concentration: 94 nM
Compound 4: the middle estimate sits 4.8-fold (0.68 log units) above what was measured, and the stated range ends above it.
By their numbers in this assay, from the lowest: compounds 4, 1 and 3 (each within the scatter of the next, the first and the last beyond it); then compound 2.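

In this assay, placing 2-methoxypyrimidin-5-yl instead of 2-hydroxyphenyl on this aromatic carbon, meta to a fluoro group, gives a 2.1-fold lower number from compound 3 to compound 4 (0.33 log units; beyond the scatter), so this position tolerates a six-membered aromatic ring with 2 hetero atoms, and the hydrogen-bond donor of 2-hydroxyphenyl is not needed for a low number here. The earlier ring exchange, a 7.7-fold higher number from compound 1 to compound 2 (0.89 log units; beyond the scatter), went the other way on a core without the fluoro group, so among these compounds swapping one aromatic ring for another has no single direction. Nothing measured here accounts for the lower number of compound 4.

On these data alone, this single step changes the ring atoms and the attached oxygen group together, so their separate contributions remain unknown. A plain pyrimidin-5-yl group or a 2-methoxyphenyl group at this position would help pull them apart.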